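The source may report more compounds than this note shows. Statements on the series, on what has been measured and on what is new or still open speak of the compounds shown alone.

Compound 1 `O=S(=O)(NCCNC(=S)Nc1cccc(Cl)c1)c1ccc(-c2ccccc2OCc2cccc(O)c2)s1`: 5800 nM
Compound 2 `O=S(=O)(NCCNC(=S)Nc1cccc(Cl)c1)c1ccc(-c2ccccc2OCc2ccccc2)s1`: > 50000 nM, a limit of the assay
Compound 3 `O=[N+]([O-])c1ccc(Oc2ccccc2-c2ccc(S(=O)(=O)NCCNC(=S)Nc3cccc(Cl)c3)s2)cc1`: > 50000 nM, a limit of the assay

Among the compounds with values here, in a functional assay on RS4-11 cells (Homo sapiens) for inhibition, read by CCK-8 assay, with a stated time of 48 h (a lower number here means a stronger inhibitor, a higher number a weaker inhibitor), compound 1 gives 5800 nM, the only true number in this small set. Compound 2 and compound 3 give no number, only (the limit of > 50000 nM in this assay, at which 2 of the 3 values shown sit).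

Compound 4 `COc1ccc(NC(=O)NCCNS(=O)(=O)c2ccc(-c3ccccc3OCc3cccc(O)c3)s2)cc1` keeps the core of compound 1 and differs on an amine nitrogen, where (4-methoxyphenyl)carbamoyl enters: a group of 11 heavy atoms (8 carbon, 1 nitrogen, 2 oxygen; one six-membered aromatic ring of carbon only) in place of a group of 10 heavy atoms (7 carbon, 1 nitrogen, 1 sulfur, 1 chlorine; one six-membered aromatic ring of carbon only), on an amine nitrogen.

Within the data shown here, no measured step touches this group. The two readable steps lie elsewhere in the molecule. Loss of the hydroxy gave an at least 8.6-fold higher number from compound 1 to compound 2 (0.93 log units; beyond the scatter), and 4-nitrophenyl in place of 3-hydroxybenzyl on the oxygen gave an at least 8.6-fold higher number from compound 1 to compound 3 (0.93 log units; beyond the scatter). Compound 4 keeps the 3-hydroxybenzyl group, so neither penalty is expected to apply, and the data give no size for the new change.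

A modest move towards a higher number in this assay is expected, with an estimated 1.4-fold higher number from compound 1 to compound 4 (0.14 log units; within the scatter). The expected value for compound 4 is 8000 nM, with an estimated range of 2500 nM to 30000 nM.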

Compound 4, half-maximal inhibitory concentration: 9400 nM
Estimate against measurement, compound 4: 1.2-fold (0.07 log units) below, and the stated range covers the measured number.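

In this assay, replacing the group on the amine nitrogen with (4-methoxyphenyl)carbamoyl gives a 1.6-fold higher number from compound 1 to compound 4 (0.21 log units; within the scatter), so the data do not separate the two groups. The earlier steps shown here concerned only the hydroxy and the group on the oxygen, whereas this one shows that the group on the amine nitrogen can be exchanged, with its sulfur and chlorine gone and a further oxygen present, without a step beyond the scatter. The data shown offer no measured property that bears on this result.

Because the exchange alters the linking unit and the ring substituents together, the compounds shown leave open what each of these contributes alone. They also leave open whether an acetyl group, a carboxylic acid or a longer chain on this amine nitrogen would keep the value of compound 4.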